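Working notes: aryl swap on compound 2 in a weak series

The compounds below may be only part of what the source reports. "The series", "measured", "known", "first", "only" and "open" are said of these compounds alone.

Measured so far:
compound 1 `CN(c1ncccc1CNc1nc(Nc2ccc3c(c2)CC(=O)N3)nc2[nH]cc(C#N)c12)S(C)(=O)=O`: > 100000 nM
compound 2 `CN(c1ncccc1CNc1nc(Nc2ccc(F)cc2)nc2[nH]cc(F)c12)S(C)(=O)=O`: 27900 nM

In a functional assay on SMMC-7721 cells (Homo sapiens) for inhibition, read by MTT assay, with a stated time of 48 h (a higher number here means a weaker inhibitor, a lower number a stronger inhibitor), compound 1 gives only a limit, > 100000 nM, not a number. Within the data shown here, compound 2 is therefore the one compound of the pair with a measured value, 27900 nM in this assay, a weak result; the other value shown sits at the limit of > 100000 nM in this assay, at which 1 of the 2 values shown sits. Among the measured compounds shown here, no pair of measured compounds differs in a single place, so no measured step exists to set a scale for the change that follows.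

Compound 3 `COc1ccc(Nc2nc(NCc3cccnc3N(C)S(C)(=O)=O)c3c(F)c[nH]c3n2)cc1OC` differs from compound 2 by 3,4-dimethoxyphenyl in place of 4-fluorophenyl on a nitrogen on an aromatic ring. For the measured compounds named here, with no measured step to lean on, the expected step from compound 2 to compound 3 in this assay, a 1.1-fold lower number from compound 2 to compound 3 (0.05 log units; within the scatter), is small and not clearly beyond the scatter in either direction. Compound 3 is thus estimated at 25000 nM in this assay, with a range of 6000 nM to 100000 nM.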

Compound 3, half-maximal inhibitory concentration: 54800 nM
For compound 3 the middle estimate is 2.2-fold (0.34 log units) below the measured one; low and high end bracket the measured number.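

In this assay, among these compounds, the one single-place change available gives a 2.0-fold higher number from compound 2 to compound 3 (0.29 log units; within the scatter), so this step cannot be told apart from repeat-measurement noise. On a nitrogen on an aromatic ring, 3,4-dimethoxyphenyl, with 10 heavy atoms, thus reads the same as 4-fluorophenyl, with 7, and both compound 2 and compound 3 remain weak. Compound 1 gives only a limit, not a number: the limit of > 100000 nM in this assay, at which 1 of the 3 values shown sits.

As far as these compounds go, with only these two aryl groups compared at this nitrogen, it remains open whether any group here can take the series out of the weak range. A phenyl ring carrying an amine or a carboxylic acid at this place might read differently, and the compounds shown give no indication either way.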